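The compounds below may be only part of what the source reports. "The series", "measured", "known", "first", "only" and "open" are said of these compounds alone.

Compound 1 `[N-]=[N+]=NCC(O)Cn1c(=O)n(C2OC(CO)[C@@H](O)[C@H]2O)c2nc(N)nc(O)c21` gives 91% in a functional assay on the whole organism (B cells) with Mus musculus as the target; on this read-out lower numbers stand for smaller maximal responses and higher numbers for larger maximal responses.
Compound 2 `C=CCn1c(=O)n(C2CN(CCCC)CC(CO)O2)c2nc(N)nc(O)c21` gives 38% in this assay.
Compound 3 `C=CCn1c(=O)n(C2C=CC(CO)O2)c2nc(N)nc(O)c21` gives 45% in this assay.

Among the measured compounds shown here, of the three measured compounds, compound 1 stands highest in this assay; its value lies beyond the scatter above both compound 3 and compound 2, which share a common core with it but differ from it in more than one place, so no single step between them can be read. Compound 4 `Nc1nc(O)c2c(n1)n(C1OC(CO)[C@@H](O)[C@H]1O)c(=O)n2Cc1ccc([N+](=O)[O-])cc1` has not yet been measured. It differs from compound 1 in one place: 4-nitrophenyl in place of 2-azido-1-hydroxyethyl on a saturated chain carbon bound to an aromatic nitrogen. For the measured compounds named here, with no measured pair that isolates this change, the size of the step is open; the lower values of compound 2 and compound 3, both carrying different side chains, give only a loose hint that moving away from the side chain of compound 1 may lower the maximal response. Compound 4 is therefore expected to give 65% in this assay, with a range from 30% to 100%. The expected step of a number 26 percentage points lower from compound 1 to compound 4 (beyond the scatter) is a moderate decrease, though a result within the scatter of compound 1 would not be surprising.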

Compound 4, largest response reached (reported as maximal response), in percent of the reference or control that the assay uses: 147%
For compound 4 the middle estimate is 82 percentage points below the measured one; the whole stated range lies below it.
By their numbers in this assay, from the lowest: compounds 2 and 3 (each within the scatter of the next); then compound 1; then compound 4.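

In this assay, the change from 3-azido-2-hydroxypropyl to 4-nitrobenzyl on the shared core gives a number 56 percentage points higher from compound 1 to compound 4 (beyond the scatter), a large rise that compounds 2 and 3, which differ from compound 1 in more than one place, could not reveal. It shows that this place, a saturated chain carbon bound to an aromatic nitrogen, can carry a six-membered aromatic ring, and that the maximal response does not fall when the hydroxyl-bearing, azide-bearing side chain and its hydrogen-bond donor are given up. Nothing available explains why this change raises the response.

This one step swaps the whole group, so the share of the aromatic ring, the nitro group and the lost hydroxyl cannot be separated. On these data alone, whether a plain benzyl, a 4-aminobenzyl or a 4-carboxybenzyl group would give a similar response remains open.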